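Notes on replacing 2,4-dichlorophenyl with 3,5-dimethylphenyl

A few compounds are considered here, and "the series" means these few. Any claim that something is new, unique, unknown or untested is made for them only; others in the source may bear on it.

Measured so far in a functional assay on DU-145 cells (Homo sapiens) for inhibition, read by trypan blue exclusion, with a stated time of 96 h; a lower number here means a stronger inhibitor of growth, a higher number a weaker inhibitor of growth:
- compound 1 `O=C(/C(=C\c1ccc(Cl)cc1Cl)S(=O)(=O)c1ccc(Br)cc1)c1ccc(Cl)cc1` gives 50000 nM
- compound 2 `Cc1ccc(/C=C(\C(=O)c2ccc(Cl)cc2)S(=O)(=O)Cc2ccc(Cl)cc2Cl)s1` gives 10000 nM

Of these two numbers, compound 1 at 50000 nM holds the higher, making it the weaker inhibitor of growth, and the gap to compound 2 at 10000 nM lies beyond the usual scatter. Compound 2 differs from compound 1 in more than one place, so the pair isolates no single change. For the measured compounds named here, no measured pair differs in one place only.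

The next compound is compound 3 `Cc1cc(C)cc(/C=C(\C(=O)c2ccc(Cl)cc2)S(=O)(=O)c2ccc(Br)cc2)c1`, which keeps the rest of compound 1 and changes one group: 3,5-dimethylphenyl in place of 2,4-dichlorophenyl on a double-bonded chain carbon bound to a double-bonded chain carbon. Going by the values given here, with no measured precedent for this change, the expectation rests on compound 1 at 50000 nM and stays wide. The expected step of a 1.4-fold lower number from compound 1 to compound 3 (0.15 log units; within the scatter) is small, with nothing beyond the scatter anticipated in this assay and only a slight lean towards a lower number. The estimated value for compound 3 is 35000 nM with an expected range of 10000 nM to 100000 nM in this assay until the measurement is available.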

Compound 3, concentration for 50% growth inhibition: 10000 nM
Compound 3: the middle estimate sits 3.5-fold (0.54 log units) above what was measured; the range from low to high includes it.
By their numbers in this assay, from the lowest: compounds 2 and 3 (each within the scatter of the next); then compound 1.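

In this assay, the position on a double-bonded chain carbon bound to a double-bonded chain carbon now has its first single-place reading: 3,5-dimethylphenyl in place of 2,4-dichlorophenyl gives a 5.0-fold lower number from compound 1 to compound 3 (0.70 log units; beyond the scatter), a step beyond the scatter. The chlorine atoms of 2,4-dichlorophenyl are therefore not needed at this position to retain growth inhibition, since compound 3, whose entering group holds carbon only, is the stronger inhibitor of this pair. The change alters both the identity and the placing of the ring substituents at once, and nothing available here explains the step.

A 3,5-dichlorophenyl or 2,4-dimethylphenyl group at this position would separate the effect of the atoms from that of their placing, while an unsubstituted phenyl would show whether the ring needs substituents at all. Also open, from the compounds shown here alone, are whether the step keeps its size when the rest of the molecule differs, and how an aminophenyl or carboxyphenyl group would read at the same position.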